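The compounds below may be only part of what the source reports. "The series", "measured", "known", "first", "only" and "open" are said of these compounds alone.

Measured so far:
Compound 1 `O/N=C(/Nc1cccc(Br)c1)c1ccc2occc2c1`: 1100 nM
Compound 2 `CCCCOc1cccc(N/C(=N/O)c2ccc3occc3c2)c1`: > 30000 nM

In an assay on tissue (HeLa cells) for inhibition of Indoleamine 2,3-dioxygenase 1 (Homo sapiens), read by spectrophotometry (on this read-out higher numbers stand for weaker inhibition and lower numbers for stronger inhibition), compound 2 gives only a limit, > 30000 nM, so its true number is not known. Compound 3 `O/N=C(/Nc1cccc(COc2ccccc2)c1)c1ccc2occc2c1` differs from compound 2 in one place: phenoxymethyl in place of butoxy on an aromatic carbon. For the measured compounds named here, one measured step touches this same place: an at least 27-fold higher number from compound 1 to compound 2 (1.43 log units; beyond the scatter), and that step ends at the limit of > 30000 nM in this assay, at which 1 of the 2 values shown sits. Both butoxy and phenoxymethyl carry one oxygen and one hydrogen-bond acceptor on the same aromatic carbon, so the step from compound 2 to compound 3 is expected to be small, an at least 1.5-fold lower number from compound 2 to compound 3 (0.17 log units; that floor lies within the scatter), though the limit leaves it uncertain. Compound 3 is estimated at 20000 nM, with a range from 5000 nM to 60000 nM.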

Compound 3, half-maximal inhibitory concentration: > 30000 nM
Compound 3: only a limit was reported; the forecaster's own chance of this, stated with the estimate: 50%; at least 1.5-fold (0.17 log units) between middle value and limit.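

In this assay, phenoxymethyl in place of bromo on this aromatic carbon gives an at least 27-fold higher number from compound 1 to compound 3 (1.43 log units; beyond the scatter). A group with a six-membered aromatic ring therefore ends at the same limit as butoxy, so neither replacement keeps the measurable inhibition of compound 1. The step between compound 2 and compound 3 cannot be read, and the two groups cannot be ranked, as both values are limits: the limit of > 30000 nM in this assay, at which 2 of the 3 values shown sit.

Going by these compounds, whether chloro, methyl or an amine on this carbon would keep the inhibition seen with compound 1 stays open. On these data alone, how far the true values of compound 2 and compound 3 lie past the limit also stays open.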